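This account rests on a few compounds, and the source may have more. Where it says the series, first, only, none or still open, it means among the compounds named here.

Measured so far:
compound 1 `Cn1cc(C(N)=O)c2c(N)ncnc21` — > 100000 nM
compound 2 `Cn1cc(C(=N)S)c2c(N)ncnc21` — 15000 nM
compound 3 `N#Cc1cn(COCc2ccccc2)c2ncnc(N)c12` — > 100000 nM

In a functional assay on KB cells (Homo sapiens) for cytotoxicity (a higher number here means a weaker inhibitor, a lower number a stronger inhibitor), compound 1 gives > 100000 nM, which is a limit of the assay and not a number. Compound 3 likewise sits at a limit, > 100000 nM, in this assay. For the measured compounds named here, compound 2 is the only one of the three with a measured number, 15000 nM, and the single measured step, an at least 6.6-fold lower number from compound 1 to compound 2 (0.82 log units; beyond the scatter), concerns the group on the aromatic carbon, not the substituent on the aromatic nitrogen.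

Compound 4 `COCCOCn1cc(C(N)=O)c2c(N)ncnc21` differs from compound 1 at that nitrogen substituent: 2-methoxyethoxy in place of hydrogen on a saturated chain carbon bound to an aromatic nitrogen. Going by the values given here, no measured step touches this position, so nothing here speaks for a change in this assay beyond the scatter; what is known is that compound 1 stands at the limit of > 100000 nM in this assay, at which 2 of the 3 values shown sit, as does compound 3, which also carries a larger group on the aromatic nitrogen.

The expectation for compound 4 is therefore that it remains near the limit, with a step that the limit leaves unreadable from compound 1 to compound 4 estimated. Compound 4 is expected at 150000 nM in this assay, within 50000 nM to 500000 nM, most likely reported as a limit again.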

Compound 4, half-maximal inhibitory concentration: > 100000 nM
Compound 4 gave a limit, no number; the forecaster's own chance of this, stated with the estimate: 75%; the middle value is on the limit's open side.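

In this assay compound 4 gives > 100000 nM as a limit and not a number. For the compounds shown here, with compound 1 also at a limit, no step between compound 1 and compound 4 can be read: the limit of > 100000 nM in this assay, at which 3 of the 4 values shown sit.

The compounds shown leave open what 2-methoxyethoxy does at this place when the aromatic carbon carries the group of compound 2, the only compound here with a measured number.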